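A few compounds are considered here, and "the series" means these few. Any claim that something is new, unique, unknown or untested is made for them only; others in the source may bear on it.

Compound 1, `Cc1ccc(C(=O)c2ccc(OCC(=O)Nc3nc(-c4ccccc4)cs3)c(C)c2)cc1`, was tested in a functional assay on Ehrlich cells (Mus musculus) for cytotoxicity, read by trypan blue exclusion, with a stated time of 48 h (a lower number here means a stronger inhibitor, a higher number a weaker inhibitor), where compound 1 gives 28400 nM. Compound 2, `COc1ccc(-c2csc(NC(=O)COc3ccc(C(=O)c4ccc(C)cc4)cc3C)n2)cc1`, carries methoxy in place of hydrogen on an aromatic carbon on an otherwise unchanged core, and in this assay compound 2 gives 19400 nM. The step is a 1.5-fold lower number from compound 1 to compound 2 (0.17 log units; within the scatter). Compound 3, `Cc1cc(C(=O)c2ccccc2)cc(C)c1OCC(=O)Nc1nc(-c2ccccc2)cs1`, is made of the same atoms as compound 1 joined in a different way; the difference between the two cores is not broken down here. In this assay compound 3 gives 22100 nM, a number close to those of compound 1 and compound 2, so no order among the three can be claimed. Compound 4, `COc1ccc(-c2csc(NC(=O)COc3c(C)cc(C(=O)c4ccccc4)cc3C)n2)cc1`, stands to compound 3 as compound 2 stands to compound 1: it carries methoxy in place of hydrogen on an aromatic carbon, at a place described in exactly the same words, so the change is the same one. Because the same change produced a 1.5-fold lower number from compound 1 to compound 2 (0.17 log units; within the scatter), the step expected here is similarly small, a 1.3-fold lower number from compound 3 to compound 4 (0.11 log units; within the scatter). Compound 4 is thus estimated at 17000 nM, with a likely range from 8000 nM to 36000 nM.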

Compound 4, half-maximal inhibitory concentration: 40600 nM
Compound 4: middle estimate off by 2.4-fold (0.38 log units), on the low side; measured number above the stated range.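

In this assay the change from phenyl to 4-methoxyphenyl gives a 1.8-fold higher number from compound 3 to compound 4 (0.26 log units; within the scatter) on this second core. Each step is small on its own, but set side by side they show that the change does not carry over as one fixed shift from one core to the other: the same change on two cores in this assay, a 1.5-fold lower number (0.17 log units; within the scatter) from compound 1 to compound 2 and a 1.8-fold higher number (0.26 log units; within the scatter) from compound 3 to compound 4, 2.7-fold (0.43 log units) apart, beyond the scatter of two such steps. Within the data shown here, this rests on only two steps, so it does not show what in the cores makes them answer differently, nor how the same change would behave on a further core.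

The compounds shown leave open whether any other group at this place, such as a hydroxyl, an amine or a carboxylic acid, would give a step that holds on both cores. They also leave open whether a change at another part of these molecules, such as a longer chain in the linker that carries the amide, would transfer between the cores any better than methoxy does.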